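Methoxy to methylamino on a purine-like core

A few compounds are considered here, and "the series" means these few. Any claim that something is new, unique, unknown or untested is made for them only; others in the source may bear on it.

Measured compounds:
- compound 1, `CCCCCCCCCC(CCO)n1cnc2c(OC)ncnc21`: 2530 nM
- compound 2, `CCCCCCCCCC(CCO)n1cnc2c(NC)ncnc21`: 5410 nM
- compound 3, `CCCCCCCCCCC(CCO)n1cnc2c(OC)ncnc21`: 7530 nM

All three were read in a functional assay on HCT-116 cells (Homo sapiens) for antiproliferative activity, read by MTT assay, with a stated time of 48 h; a lower number here means a stronger inhibitor, a higher number a weaker inhibitor. Compound 1 gives the lowest number of the three; compound 2 and compound 3 lie within the usual scatter of each other, so nothing is said about their order.

Two single changes are covered. From compound 1 to compound 2 the change is methylamino in place of methoxy on an aromatic carbon, and the step is a 2.1-fold higher number from compound 1 to compound 2 (0.33 log units; beyond the scatter). From compound 1 to compound 3 the change is methyl in place of hydrogen on a saturated chain carbon, ten or more bonds along the chain from an aromatic nitrogen, a change on the chain rather than the ring, and the step is a 3.0-fold higher number from compound 1 to compound 3 (0.47 log units; beyond the scatter).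

Compound 4, `CCCCCCCCCCC(CCO)n1cnc2c(NC)ncnc21`, is not yet measured. It differs from compound 3 by methylamino in place of methoxy on an aromatic carbon, which is the same change as that from compound 1 to compound 2: the place lines read alike word for word. The two cores, that of compound 3 and that of compound 1, differ only by methyl in place of hydrogen on a saturated chain carbon, ten or more bonds along the chain from an aromatic nitrogen. Within the data shown here, only one prior example of this change exists, namely a 2.1-fold higher number from compound 1 to compound 2 (0.33 log units; beyond the scatter). A step of about that size is expected here, so a modest rise in the number is expected, a 2.0-fold higher number from compound 3 to compound 4 (0.30 log units; within the scatter). Among the measured compounds shown here, compound 4 is therefore estimated at 15000 nM, with a range from 6000 nM to 40000 nM to allow for the scatter and for the single precedent.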

Compound 4, half-maximal inhibitory concentration: 12700 nM
Beside the measured number, compound 4's estimate is 1.2-fold (0.07 log units) above it, and the stated range covers the measured number.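

In this assay, methylamino in place of methoxy on the core of compound 3 gives a 1.7-fold higher number from compound 3 to compound 4 (0.23 log units; within the scatter), and this step cannot be told apart from the one on the core of compound 1: the same change on two cores in this assay, a 2.1-fold higher number (0.33 log units; beyond the scatter) from compound 1 to compound 2 and a 1.7-fold higher number (0.23 log units; within the scatter) from compound 3 to compound 4, 1.3-fold (0.10 log units) apart, within the scatter of two such steps. The chain change, methyl in place of hydrogen on a saturated chain carbon, gives a 2.3-fold higher number from compound 2 to compound 4 (0.37 log units; beyond the scatter) with methylamino on the aromatic carbon, and it also matches its earlier counterpart with methoxy there: the same change on two cores in this assay, a 3.0-fold higher number (0.47 log units; beyond the scatter) from compound 1 to compound 3 and a 2.3-fold higher number (0.37 log units; beyond the scatter) from compound 2 to compound 4, 1.3-fold (0.10 log units) apart, within the scatter of two such steps. Each change therefore carries across these two cores with no measurable difference in step size, but the step on the core of compound 3 lies within the scatter on its own, and this single set of four compounds in one assay establishes no rule for other cores or assays and gives no reason for either step.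

The compounds shown leave open whether the same agreement holds for other groups on that aromatic carbon, such as an unsubstituted amine, dimethylamino or chlorine. Also open, going by these compounds, is how the steps behave with a shorter or longer chain, or with a carboxylic acid in place of the hydroxyl.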